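A few compounds are considered here, and "the series" means these few. Any claim that something is new, unique, unknown or untested is made for them only; others in the source may bear on it.

Measured in a functional assay on HeLa cells (Homo sapiens) for inhibition, read by MTT assay, with a stated time of 24 h; a higher number here means a weaker inhibitor, a lower number a stronger inhibitor:
- compound 1 `C/C=C(\C)C(=O)O[C@@H]1[C@]2(OC(=O)CCCC)C=C3C4=CC(=O)O[C@@H](c5ccoc5)[C@]4(C)CC[C@@H]3[C@@]3(C)[C@H](C[C@]1(C)[C@H]3[C@@H](O)C(=O)OC)O2`: > 100000 nM, a limit
- compound 2 `C/C=C(\C)C(=O)O[C@@H]1[C@]2(OC(=O)C3CC3)C=C3C4=CC(=O)O[C@@H](c5ccoc5)[C@]4(C)CC[C@@H]3[C@@]3(C)[C@H](C[C@]1(C)[C@H]3[C@@H](O)C(=O)OC)O2`: > 100000 nM, a limit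

Compound 2 has no exact number in this assay, only a limit, and compound 1 is in the same position: the limit of > 100000 nM in this assay, at which 2 of the 2 values shown sit. Compound 3 `C/C=C(\C)C(=O)O[C@@H]1[C@]2(OC(=O)C3CC3)C=C3C4=CC(=O)O[C@@H](c5ccoc5)[C@]4(C)CC[C@@H]3[C@@]3(C)[C@H](C[C@]1(C)[C@H]3[C@@H](OC(=O)C1CC1)C(=O)OC)O2` differs from compound 2 by one change: cyclopropylcarbonyl in place of hydrogen on an oxygen on a saturated carbon. A hydroxy group thus becomes (cyclopropylcarbonyl)oxy, with cyclopropylcarbonyl in place of hydrogen on an oxygen on a saturated carbon. Going by the values given here, the only measured step, a step that the two limits leave unreadable from compound 1 to compound 2, swaps butyl for cyclopropyl on a carbonyl carbon, at a different place, and has no readable size. It therefore suggests no direction, and no step beyond the scatter is expected in this assay. The estimated step is a number no higher from compound 2 to compound 3 (the limit leaves the size open). Compound 3 is expected at 100000 nM, with an estimated range of 40000 nM to 250000 nM, and the result may well be reported only as a limit.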

Compound 3, half-maximal inhibitory concentration: > 100000 nM
Compound 3 gave a limit, no number; the forecaster's own chance of this, stated with the estimate: 80%; the middle value lies on the limit itself.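

In this assay, going by these compounds alone, compound 3 gives only a limit, as compound 2 does, so no step from compound 2 to compound 3 can be read: the limit of > 100000 nM in this assay, at which 3 of the 3 values shown sit.
With no exact number for any of them, the compounds shown leave open how strongly each inhibits and whether (cyclopropylcarbonyl)oxy in place of hydroxy changes inhibition at all.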